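A few compounds are considered here, and "the series" means these few. Any claim that something is new, unique, unknown or untested is made for them only; others in the source may bear on it.

Of the compounds shown here, three from this series have been measured in a physicochemical assay for lipophilicity, using the shake flask method, in phosphate buffer, measured as octanol-water partition, with a stated time of 30 min, at pH 7.4; a lower number here means a more polar compound, a higher number a more lipophilic compound. Compound 1 `Cn1cc(-c2cnc(NCc3c(F)ccc4c3CCO4)c3cn[nH]c(=O)c23)cn1` gives 2.7. Among the compounds with values here, compound 2 `Cc1nccn1-c1cnc(NCc2c(F)ccc3c2CCO3)c2cn[nH]c(=O)c12` gives 2.1, and the only step between directly comparable compounds is a number 0.60 log units lower from compound 1 to compound 2 (beyond the scatter). Compound 3 `C[C@@H]1CC(=O)N(c2cnc(NCc3c(F)ccc4c3CCO4)n3cnnc23)C1` gives 1.8, the lowest of the three numbers, though compound 2 stands within the usual scatter of it, while compound 1 stands beyond that scatter above it.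

Compound 4 `C[C@H]1CC(=O)N(c2cnc(NCc3c(F)ccc4c3CCO4)n3cnnc23)C1` is the next compound to be placed in this assay. Its relation to compound 3 is the two compounds have the same atoms and bonds and differ only in configuration as drawn: 1 of 1 stereo elements differ; a stereocentre at a saturated ring carbon is drawn R in compound 3 and S in compound 4. Within the data shown here, none of the measured steps involves a change of configuration alone: the one step on record, from compound 1 to compound 2, exchanges one ring for another on an aromatic carbon and says nothing about a stereocentre at a saturated ring carbon. Two compounds with the same atoms and bonds that differ only in configuration are not expected to part ways in this assay, so no step beyond the scatter is expected, and the expected step from compound 3 is no change at the digits printed from compound 3 to compound 4 (within the scatter). Compound 4 is therefore estimated at 1.8, with a range from 1.5 to 2.1.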

Compound 4, distribution coefficient: 1.8
Estimate against measurement, compound 4: no gap at the digits printed; measured number inside the range.
By their numbers in this assay, from the lowest: compounds 3, 4 and 2 (each within the scatter of the next); then compound 1.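

Turning the stereocentre at a saturated ring carbon from R to S leaves this assay with no change at the digits printed from compound 3 to compound 4 (within the scatter). Within the data shown here, this is the first reading of a change of configuration alone, whereas the only earlier step, a number 0.60 log units lower from compound 1 to compound 2 (beyond the scatter), exchanged one ring for another on an aromatic carbon and could say nothing about a stereocentre. The new step can be assigned to the configuration at this one carbon, with no other structural change to separate from it, for one reason: the fact that compounds 3 and 4 differ only in the configuration as drawn

Still open, from the compounds shown here alone, is how this assay would respond if the methyl group at this stereocentre gave way to an ethyl group, a hydroxyl group or an amine, as the pair shows only that swapping the configuration of the methyl-bearing carbon leaves the number where it was. Also open is whether the same two configurations would stay together in a measurement of another kind, as only this one read-out is shown for them.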